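Bromo to Nitro on a Shared Core, Cytotoxicity Unresolved

The source may hold more compounds than are shown below. What is called first, only, known or untested is meant among the compounds shown, and "the series" means these compounds.

Compound 2 `CCOC(=O)CCCCCOc1cccc(CN(C(=O)c2ccc(-c3cccc(Br)c3)cc2)C(C)C)c1` has been tested in an ADME assay on BJ cells (Homo sapiens) for cytotoxicity, read by CellTiter-Glo and resazurin assay, with a stated time of 72 h; on this read-out higher numbers stand for an effect only at larger amounts of compound and lower numbers for an effect already at smaller amounts. In this assay compound 2 gives only a limit, > 26000 nM. Compound 1 `CCOC(=O)CCCCCOc1cccc(CN(C(=O)c2ccc(-c3cnc(OC)nc3OC)cc2)C(C)C)c1` shares the same core and the same chain. In this assay compound 1 likewise gives only a limit, > 26000 nM. Among the compounds with values here, the single measured step, a step that the two limits leave unreadable from compound 1 to compound 2, therefore cannot be sized; the limit of > 26000 nM in this assay, at which 2 of the 2 values shown sit, marks the limit at which both values sit. The unmeasured compound 3 `CCOC(=O)CCCCCOc1cccc(CN(C(=O)c2ccc(-c3cccc([N+](=O)[O-])c3)cc2)C(C)C)c1` differs from compound 2 by nitro in place of bromo on an aromatic carbon. Within the data shown here, no measured step bears directly on this change, and the only step known is itself unreadable. With both known values at the limit, compound 3 is expected to stay at that limit as well, the expected step in this assay being a step that the limit leaves unreadable from compound 2 to compound 3. Compound 3 is estimated at 30000 nM, within 15000 nM to 80000 nM, and most likely reported once more as a limit.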

Compound 3, half-maximal effective concentration: < 1.3 nM
Compound 3: only a limit was reported; the forecaster's own chance of this, stated with the estimate: 85%; at least 23000-fold (4.36 log units) between middle value and limit.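

In this assay, a single change on this aromatic ring can move the read-out, which the earlier pair did not show: nitro in place of bromo gives an at least 20000-fold lower number from compound 2 to compound 3 (4.30 log units; beyond the scatter), and 3-nitrophenyl in place of 2,4-dimethoxypyrimidin-5-yl gives an at least 20000-fold lower number from compound 1 to compound 3 (4.30 log units; beyond the scatter). Compound 3 gives only a limit, at the low end of the values shown: the limit of < 1.3 nM in this assay, at which 1 of the 3 values shown sits. The step from compound 1 to compound 2 still cannot be read, and both compounds remain at the opposite limit: the limit of > 26000 nM in this assay, at which 2 of the 3 values shown sit.

As far as these compounds go, the full size of both new steps remains open, as each rests on limits. Also open, from the compounds shown here alone, is whether an amine or a nitrile on the same ring carbon would give the same result as nitro, and whether compound 3 would keep its value with a carboxylic acid at the end of its chain.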